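The source may hold more compounds than are shown below. What is called first, only, known or untested is meant among the compounds shown, and "the series" means these compounds.

Two compounds share the dithiocarbamate-bearing chromone core. Compound 1 `O=c1c(SC(=S)N2CCCCC2)coc2ccccc12` gives 7800 nM in a functional assay on LM7 cells (Homo sapiens) for antiproliferative activity, read by MTT assay, with a stated time of 72 h (on this read-out higher numbers stand for weaker inhibition and lower numbers for stronger inhibition), the lowest of the two numbers on hand. Compound 2 `O=c1cc(CSC(=S)N2CCN(c3ccccc3)CC2)oc2cc(Cl)ccc12` gives 15900 nM in this assay, a number beyond the scatter from compound 1; the two differ in several places at once, so no single change can be read from them. Compound 3 `O=c1c(SC(=S)N2CCCCC2)coc2ccc(Cl)cc12` differs from compound 1 by chloro in place of hydrogen on an aromatic carbon. For the measured compounds named here, with no comparable pair measured, only a modest step is expected, a 1.1-fold lower number from compound 1 to compound 3 (0.05 log units; within the scatter), within the scatter. Compound 3 is thus estimated at 7000 nM, between 3000 nM and 16000 nM.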

Compound 3, half-maximal inhibitory concentration: > 25000 nM
Compound 3 ended at the assay's limit; the forecaster's own chance of this, stated with the estimate: 5%; middle value at least 3.5-fold (0.55 log units) from the limit.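

Swapping hydrogen for chloro on this aromatic carbon, meta to a fused ring and para to a fused ring, is not a neutral change: in this assay it gives an at least 3.2-fold higher number from compound 1 to compound 3 (0.50 log units; beyond the scatter), so inhibition weakens. Compound 3 reads > 25000 nM, which is a limit of the assay and not a number. The step therefore sets only a minimum size, with its true size unknown: the limit of > 25000 nM in this assay, at which 1 of the 3 values shown sits.

From the compounds shown here alone, whether fluoro, methoxy or an amine on this same carbon would keep the activity of compound 1 remains open. Also open, going by these compounds, is whether chloro here would have the same effect with a different group on the dithiocarbamate.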